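The source may hold more compounds than are shown below. What is called first, only, known or untested is meant among the compounds shown, and "the series" means these compounds.

Working notes on the series in a functional assay on MCF7 cells (Homo sapiens) for inhibition, read by sulforhodamine B assay, with a stated time of 48 h, tested at 50 uM; on this read-out higher numbers stand for more inhibition of growth at the one concentration tested and lower numbers for less inhibition of growth.

Compound 1 `COc1ccc([C@@H]2C/C(=N/OCc3cn(-c4ccccc4CO)nn3)c3cc(CC=C(C)C)c(OC)cc3O2)cc1` gives 100% in this assay. Compound 2 `CCOc1ccc([C@@H]2CC(=O)c3cc(CC=C(C)C)c(OC)cc3O2)cc1` gives 57%. Compound 3 `COc1ccc([C@@H]2C/C(=N/OCc3cn(-c4ccc(C(=O)c5ccccc5)cc4)nn3)c3cc(CC=C(C)C)c(OC)cc3O2)cc1` gives 41%, the lowest of the three numbers; its gap to compound 2 is beyond the scatter, and its gap to compound 1 is larger still and also beyond the scatter.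

Compound 4 `COc1ccc([C@@H]2C/C(=N/OCc3cn(-c4ccc(O)cc4)nn3)c3cc(CC=C(C)C)c(OC)cc3O2)cc1` is not yet measured. It differs from compound 3 in one place: hydroxy in place of benzoyl on an aromatic carbon. The change sits on an aromatic carbon of a six-membered aromatic ring of carbon only, para to a large group. For the measured compounds named here, no measured pair isolates this change, so the expectation rests on where compound 3 stands and on compound 1 carrying a hydrogen-bond donor near the same part of the shared core with 100%.

Compound 4 is expected to move upward from compound 3 by a step of a number 29 percentage points higher from compound 3 to compound 4 (beyond the scatter) in this assay, beyond the scatter but short of compound 1. The estimate for compound 4 is 70%, with a range from 42% to 95%.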

Compound 4, percent growth inhibition at one concentration: 63%
Compound 4: middle estimate off by 7 percentage points, on the high side, within the range that was stated.
By their numbers in this assay, from the lowest: compound 3; then compounds 2 and 4 (each within the scatter of the next); then compound 1.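

In this assay, replacing benzoyl with hydroxy on this aromatic carbon, para to a large group, gives a number 22 percentage points higher from compound 3 to compound 4 (beyond the scatter), the first direct sign that the number responds to the group at this place. The hydroxy does not account for the full level seen in the series: 4-hydroxyphenyl in place of 2-(hydroxymethyl)phenyl on the aromatic nitrogen gives a number 37 percentage points lower from compound 1 to compound 4 (beyond the scatter), so a hydroxy-bearing aryl group on that nitrogen does not by itself settle the number. Nothing available here explains either step.

The compounds shown do not separate the loss of benzoyl from the arrival of hydroxy, and they leave open how a methoxy, an amine or a carboxylic acid would read at this aromatic carbon. Also open, from the compounds shown here alone, is how a hydroxymethyl would read at this same place.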